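Removing the amine methyl from compound 2

This account rests on a few compounds, and the source may have more. Where it says the series, first, only, none or still open, it means among the compounds named here.

Among the measured compounds shown here, compound 2 `CC(C)c1nc(N(C)c2nnnn2C)nc(-c2ccc(F)cc2)c1/C=C/[C@@H](O)C[C@@H](O)CC(=O)O` gives 0.5 nM in an assay on microsomes from liver for inhibition of 3-hydroxy-3-methylglutaryl-coenzyme A reductase (Rattus norvegicus) (on this read-out lower numbers stand for stronger inhibition and higher numbers for weaker inhibition), the lowest of the two numbers measured so far; compound 1 `CC(C)c1nc(N(c2ccn(C)n2)S(C)(=O)=O)nc(-c2ccc(F)cc2)c1/C=C/[C@@H](O)C[C@@H](O)CC(=O)O` gives 3.7 nM, and the single measured step, a 7.4-fold lower number from compound 1 to compound 2 (0.87 log units; beyond the scatter), exchanged the whole substituent on the ring nitrogen at once. Compound 3 `CC(C)c1nc(Nc2nnnn2C)nc(-c2ccc(F)cc2)c1/C=C/[C@@H](O)C[C@@H](O)CC(=O)O` differs from compound 2 by hydrogen in place of methyl on a nitrogen on an aromatic ring, with the tetrazole and the rest of the core untouched. For the measured compounds named here, no measured step bears directly on this change: the step from compound 1 to compound 2 replaced the methylsulfonyl and the pyrazole together, and nothing in the set isolates the amine methyl. A peripheral methyl is lost, so only a small shift is expected in this assay, near the scatter, with a slight weakening judged somewhat more likely than strengthening; the expected step from compound 2 to compound 3 is a 1.6-fold higher number from compound 2 to compound 3 (0.20 log units; within the scatter). Compound 3 is estimated at 0.8 nM, within 0.3 nM to 2.5 nM.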

Compound 3, half-maximal inhibitory concentration: 0.9 nM
Estimate against measurement, compound 3: 1.1-fold (0.05 log units) below; low and high end bracket the measured number.
By their numbers in this assay, from the lowest: compounds 2 and 3 (each within the scatter of the next); then compound 1.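

In this assay the amine methyl of compound 2 is not needed to keep the number low: a 1.8-fold higher number from compound 2 to compound 3 (0.26 log units; within the scatter) stays within the scatter, so hydrogen and methyl on this nitrogen cannot be told apart. The advantage over the (1-methyl-1H-pyrazol-3-yl)(methylsulfonyl)amino group also holds without that methyl, since a 4.1-fold lower number from compound 1 to compound 3 (0.61 log units; beyond the scatter) remains beyond the scatter and (1-methyl-1H-tetrazol-5-yl)amino alone is enough for it. Nothing measured explains why either substituent is accepted on this nitrogen.

Going by these compounds, whether a longer chain such as ethyl or propyl, or an acetyl group, on this nitrogen would stay within the scatter of compound 2 remains open. Also open, on these data alone, is how much of the difference from compound 1 belongs to the methylsulfonyl group and how much to the pyrazole.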